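This account rests on a few compounds, and the source may have more. Where it says the series, first, only, none or still open, it means among the compounds named here.

Measured so far:
compound 1 `CC(=O)c1coc(C(=O)CCCCCCc2ccccc2)n1` — 123 nM
compound 2 `CSc1coc(C(=O)CCCCCCc2ccccc2)n1` — > 10000 nM

In an assay on HEK-293T cells for inhibition of diacylglycerol lipase-alpha (Homo sapiens), read by colorimetric assay (a higher number here means a weaker inhibitor, a lower number a stronger inhibitor), compound 1 gives 123 nM. For compound 2 the reported > 10000 nM is a limit of the assay and not a number, which is the limit of > 10000 nM in this assay, at which 1 of the 2 values shown sits. Compound 2 therefore stands at the weak end of the values shown, known only as a limit. Among the measured compounds shown here, the single measured step, an at least 81-fold higher number from compound 1 to compound 2 (1.91 log units; beyond the scatter), concerns the substituent on the aromatic ring rather than the ring itself. Compound 3 `COc1cnc(C(=O)CCCCCCc2ccccc2)o1` differs from compound 2 by a group of 7 heavy atoms (4 carbon, 1 nitrogen, 2 oxygen; one five-membered aromatic ring with 2 hetero atoms) in place of a group of 7 heavy atoms (4 carbon, 1 nitrogen, 1 oxygen, 1 sulfur; one five-membered aromatic ring with 2 hetero atoms), on a carbonyl carbon. For the measured compounds named here, no measured step covers an exchange of this kind, so its size in this assay cannot be read from the data; the one measured step shows only that changes at this part of the molecule can move the number a great deal. Compound 3 is expected near 8000 nM, within 1000 nM to 30000 nM. The step this estimate implies is an at least 1.2-fold lower number from compound 2 to compound 3 (0.09 log units; that floor lies within the scatter), and a further limit rather than a number is considered likely.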

Compound 3, half-maximal inhibitory concentration: > 10000 nM
Compound 3 gave a limit, no number; the forecaster's own chance of this, stated with the estimate: 60%; at least 1.2-fold (0.09 log units) between middle value and limit.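

Compound 3 gives > 10000 nM in this assay, a limit of the assay and not a number. Among the compounds shown here, compound 2 also stands at a limit, so no step between compound 2 and compound 3 can be read: the limit of > 10000 nM in this assay, at which 2 of the 3 values shown sit. The compounds shown leave open how compound 2 and compound 3 actually compare.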